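This account rests on a few compounds, and the source may have more. Where it says the series, first, only, none or still open, it means among the compounds named here.

For the measured compounds named here, compound 2 `CC(C)=CCC/C(C)=C/CC1Cc2c(OCCCNC(=O)c3ccc([N+](=O)[O-])cc3)cc(=O)n(CCCO)c2CC1(C)C` is one of two compounds measured in a functional assay on PANC-1 cells (Homo sapiens) for inhibition, read by MTT assay, with a stated time of 24 h, tested at 10 uM; a lower number here means less inhibition, a higher number more inhibition at the concentration tested (going by the name of the read-out). Compound 2 gives 16.8%, and compound 1 `CC(C)=CCC/C(C)=C/CC1Cc2c(OCCCNS(=O)(=O)c3ccc(Cl)cc3)cc(=O)n(CCCO)c2CC1(C)C` gives 14.5%; the step of a number 2.3 percentage points higher from compound 1 to compound 2 (within the scatter) is within the scatter, so compound 2 stands at the higher of the two numbers without being separable from compound 1. Compound 3 `CC(C)=CCC/C(C)=C/CC1Cc2c(OCCCOc3ccc(Cl)cc3)cc(=O)n(CCCO)c2CC1(C)C` has not yet been measured in this assay. It differs from compound 2 in that (4-chlorophenoxy in place of ((4-nitrophenyl)carbonyl)amino on a saturated chain carbon, three bonds along the chain from an oxygen on an aromatic ring). Going by the values given here, the only measured step, a number 2.3 percentage points higher from compound 1 to compound 2 (within the scatter), exchanged one group on the amine nitrogen for another and produced no change beyond the scatter, whereas the change to compound 3 removes the ((4-nitrophenyl)carbonyl)amino group entirely in favour of 4-chlorophenoxy, so that step bears on it only loosely. With nothing measured to suggest otherwise, compound 3 is expected to show a step of a number 1.8 percentage points lower from compound 2 to compound 3 (within the scatter) in this assay, within the scatter. Compound 3 is therefore estimated at 15%, with a range from 3% to 30%.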

Compound 3, a percentage reported as inhibition, at one concentration (the size of the read-out at that concentration, not a potency): 25.2%
Compound 3: the middle estimate sits 10.2 percentage points below what was measured; low and high end bracket the measured number.
By their numbers in this assay, from the lowest: compounds 1, 2 and 3 (each within the scatter of the next, the first and the last beyond it).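

For the compounds shown here, with 4-chlorophenoxy on the saturated chain carbon, three bonds along the chain from an oxygen on an aromatic ring, this assay gives the first step at this position that lies beyond the scatter: a number 10.7 percentage points higher from compound 1 to compound 3 (beyond the scatter) in the comparison with the sulfonyl compound. Since a 4-chlorophenyl ring is present in both compounds, that step comes from exchanging the sulfonylamino link for an ether oxygen, whereas the comparison with the amide, a number 8.4 percentage points higher from compound 2 to compound 3 (within the scatter), stays within the scatter and cannot separate the two. Nothing available explains why the link matters here.

On these data alone, it remains open whether 4-nitrophenoxy or unsubstituted phenoxy would give a number like that of compound 3 25.2% in this position. A longer chain carrying the same 4-chlorophenoxy, or a terminal carboxylic acid in its place, is equally untested by these compounds.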